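A Fourth Analogue Where Three Sit at the Limit

The compounds below may be only part of what the source reports. "The series", "measured", "known", "first", "only" and "open" are said of these compounds alone.

All four compounds share one core and differ only in the group attached to the amide nitrogen. Compound 1 `CCN(CC)S(=O)(=O)c1ccc(S(=O)(=O)N2CCC[C@@H](C(=O)N(C)C(C)C)C2)cc1` was tested in a functional assay on MIA PaCa-2 cells (Homo sapiens) for inhibition, read by MTT assay, with a stated time of 3 days; a higher number here means a weaker inhibitor, a lower number a stronger inhibitor. In this assay compound 1 gave > 10000 nM, which is a limit of the assay and not a number. Compound 2 `CCN(CC)C(=O)[C@@H]1CCCN(S(=O)(=O)c2ccc(S(=O)(=O)N(CC)CC)cc2)C1` in this assay gave > 10000 nM, again a limit. Compound 3 `CCN(CC)S(=O)(=O)c1ccc(S(=O)(=O)N2CCC[C@@H](C(=O)NC3CN(C(=O)NC(C)(C)C)C3)C2)cc1` in this assay gave > 10000 nM, also a limit, so compound 3 stands at the same limit as the other two.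

The steps that touch the same position are a step that the two limits leave unreadable from compound 1 to compound 3 and a step that the two limits leave unreadable from compound 2 to compound 3; neither can be sized because the limit of > 10000 nM in this assay, at which 3 of the 3 values shown sit, leaves both ends unreadable. Compound 4 `CCN(CC)S(=O)(=O)c1ccc(S(=O)(=O)N2CCC[C@@H](C(=O)N[C@H]3CCN(C(=O)OC(C)(C)C)C3)C2)cc1` differs from compound 3 by 1-(tert-butoxycarbonyl)pyrrolidin-3-yl in place of 1-((tert-butyl)carbamoyl)azetidin-3-yl on an amide-type nitrogen. Since every neighbour sits at the limit, no direction can be read from them, and compound 4 is expected to remain near that limit. Compound 4 is estimated at 15000 nM, between 4000 nM and 60000 nM. The expected step is a step that the limit leaves unreadable from compound 3 to compound 4.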

Compound 4, half-maximal inhibitory concentration: > 10000 nM
Compound 4 was reported as a limit; the forecaster's own chance of this, stated with the estimate: 80%; the middle value is on the limit's open side.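

No size can be read for the step between compound 3 and compound 4, since each is reported only as a limit and not as a number: the limit of > 10000 nM in this assay, at which 4 of the 4 values shown sit.

The compounds shown leave open how far these four actually differ, and whether any group on the amide-type nitrogen gives a measurable value.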